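The compounds below may be only part of what the source reports. "The series", "measured", "known", "first", "only" and "open" are said of these compounds alone.

Measured compounds in this assay:
compound 1 `O=C1[C@@H]2C(c3ccccc3)OC3(C(=O)c4ccccc4C3=O)[C@@H]2C(=O)N1c1ccc(Cl)c(Cl)c1`: > 100000 nM
compound 2 `COc1ccccc1N1C(=O)C2C(c3ccccc3)OC3(C(=O)c4ccccc4C3=O)C2C1=O`: > 100000 nM
compound 3 `COC(=O)C1NC(c2ccccc2)[C@H]2C(=O)N(c3ccc(Cl)c(Cl)c3)C(=O)[C@@H]12`: > 100000 nM

In an assay on isolated protein for inhibition of phenylalanine--tRNA ligase, mitochondrial (Homo sapiens) (a higher number here means a weaker inhibitor, a lower number a stronger inhibitor), compound 1 gives > 100000 nM, which is a limit of the assay and not a number. Compound 2 gives > 100000 nM, also a limit. Compound 3 gives > 100000 nM, a limit as well. All that is known is the limit of > 100000 nM in this assay, at which 3 of the 3 values shown sit, so compound 1 stands nowhere in particular among the others.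

Compound 4 `Cc1ccc(N2C(=O)[C@@H]3C(c4ccccc4)OC4(C(=O)c5ccccc5C4=O)[C@@H]3C2=O)cc1Cl` differs from compound 1 by methyl in place of chloro on an aromatic carbon. For the measured compounds named here, no step between two measured compounds exists to guide the size of this change. The expectation is that compound 4 stays at the limit, with no step beyond the scatter, so a step that the limit leaves unreadable from compound 1 to compound 4 is estimated. Compound 4 is expected at 200000 nM, between 50000 nM and 1000000 nM.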

Compound 4, half-maximal inhibitory concentration: > 100000 nM
Compound 4: only a limit was reported (the forecaster's own chance of this, stated with the estimate: 85%); the middle value lies beyond the limit too.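

In this assay compound 1 and compound 4 both give a limit and not a number, so no step can be read between them: the limit of > 100000 nM in this assay, at which 4 of the 4 values shown sit.

The compounds shown leave open whether any change to the shared core gives a measurable value.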